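Does hydroxymethyl shift compound 4 from the ester?

The compounds below may be only part of what the source reports. "The series", "measured", "known", "first", "only" and "open" are said of these compounds alone.

Results in a functional assay on KB cells (Homo sapiens) for cytotoxicity, read by MTT assay, with a stated time of 72 h; on this read-out lower numbers stand for an effect already at smaller amounts and higher numbers for an effect only at larger amounts of compound
Compound 1 `CCOc1c(-c2occ(C)c2C(=O)O)ccc2c(CC)cccc12` gives > 10 ug/mL as a limit
Compound 2 `CCCOC(=O)c1c(C)coc1-c1ccc2c(CC)cccc2c1OC` gives > 10 ug/mL as a limit
Compound 3 `CCc1cccc2c(OC)c(-c3occ(C)c3C(=O)On3nnc4ccccc43)ccc12` gives > 10 ug/mL as a limit

Compound 2 sits at the limit > 10 ug/mL and has no exact number. Going by the values given here, with the limit of > 10 ug/mL in this assay, at which 3 of the 3 values shown sit, in view, no compound here has a readable number. Compound 4 `CCc1cccc2c(OC)c(-c3occ(C)c3CO)ccc12` brings the change hydroxymethyl in place of propoxycarbonyl on an aromatic carbon and so has hydroxymethyl in place of propoxycarbonyl on an aromatic carbon. Among the compounds with values here, the one measured step here runs a step that the two limits leave unreadable from compound 2 to compound 3 and has no readable size, so it offers neither a size nor a direction to carry over. In this assay no step beyond the scatter is therefore expected. The estimated step runs a step that the limit leaves unreadable from compound 2 to compound 4 and has no firm direction. Compound 4 is estimated at 14 ug/mL with an expected range from 6 ug/mL to 30 ug/mL and may well report only a limit.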

Compound 4, concentration for half-maximal effect: 7.1 ug/mL
Estimate against measurement, compound 4: 2.0-fold (0.29 log units) above; low and high end bracket the measured number.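

In this assay, going by these compounds alone, compound 4 gives the first exact number in this set, showing that a readable effect is possible with this position on the five-membered aromatic ring changed. Hydroxymethyl in place of propoxycarbonyl brings an at least 1.4-fold lower number from compound 2 to compound 4 (0.14 log units; that floor lies within the scatter), and this is only a floor, so the true step may be larger. Compound 2 has only a limit, and it is not alone: the limit of > 10 ug/mL in this assay, at which 3 of the 4 values shown sit.

The compounds shown leave open whether the hydroxyl of hydroxymethyl matters or whether simply removing the ester is enough. An aminomethyl group or a longer chain such as hydroxyethyl at this position could separate these two readings.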